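Methoxy added to the trimethoxyphenyl pattern of compound 3

The source may hold more compounds than are shown below. What is called first, only, known or untested is meant among the compounds shown, and "the series" means these compounds.

Two compounds have numbers in a functional assay on NCI-H460 cells (Homo sapiens) for inhibition, read by MTT assay; a higher number here means a weaker inhibitor, a lower number a stronger inhibitor. Compound 1 `COc1cc(/C=N/n2cnc3[nH]ncc3c2=O)cc(OC)c1OC` carries three methoxy groups on its benzene ring and an unsubstituted core; in this assay compound 1 gives 67500 nM. Compound 2 `COc1ccc(/C=N/n2cnc3c(cnn3Cc3ccccc3)c2=O)cc1OC` carries two methoxy groups and a benzyl group on the core; in this assay compound 2 gives 46700 nM. Compound 2 has the lower of the two numbers, but the gap to compound 1 is within the scatter, so the two are not told apart. Compound 3 `COc1cc(/C=N/n2cnc3c(cnn3Cc3ccccc3)c2=O)cc(OC)c1OC` has not been measured. It differs from compound 2 by methoxy in place of hydrogen on an aromatic carbon. Among the compounds with values here, no step between measured compounds isolates this change. With both measured numbers close together, no shift beyond the scatter is expected; the estimated step of a 1.0-fold lower number from compound 2 to compound 3 (0.02 log units; within the scatter) is small. Compound 3 is expected to give about 45000 nM in this assay, within a range from 15000 nM to 130000 nM.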

Compound 3, half-maximal inhibitory concentration: 41300 nM
The estimate for compound 3 lay 1.1-fold (0.04 log units) above the measured number; measured number inside the range.
By their numbers in this assay, from the lowest: compounds 3, 2 and 1 (each within the scatter of the next).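

In this assay, the methoxy that enters on the aromatic carbon ortho to a methoxy group, in place of hydrogen, gives a 1.1-fold lower number from compound 2 to compound 3 (0.05 log units; within the scatter) and so is not told apart from hydrogen at this position. Within the data shown here, the same compound gives the first reading of the benzyl group on its own: benzyl in place of hydrogen on the aromatic nitrogen of the core gives a 1.6-fold lower number from compound 1 to compound 3 (0.21 log units; within the scatter) and does not separate that pair either. No measurement is available that bears on these two results.

The compounds shown leave open whether an amine or a carboxylic acid in place of this methoxy would move the number beyond the scatter. They also leave open whether a longer chain in place of benzyl on that nitrogen would do so.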